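The source may hold more compounds than are shown below. What is called first, only, known or untested is meant among the compounds shown, and "the series" means these compounds.

Compound 1, `Cc1ccc(-c2noc(CCCCCCC(=O)NO)n2)cc1`: 5390 nM
Compound 2, `Cc1ccc(-c2noc(CCCCCCC(=O)C(F)(F)F)n2)cc1`: 3190 nM

In an assay on isolated protein for inhibition of histone deacetylase 8 (Homo sapiens), read by fluorescence, with a stated time of 10 min (a lower number here means a stronger inhibitor, a higher number a weaker inhibitor), compound 2 gives 3190 nM, the lowest of the two numbers shown, though the single measured step, a 1.7-fold lower number from compound 1 to compound 2 (0.23 log units; within the scatter), lies within the scatter. Compound 3, `O=C(CCCCCCc1nc(-c2ccc(F)cc2)no1)C(F)(F)F`, differs from compound 2 by fluoro in place of methyl on an aromatic carbon. Within the data shown here, no measured step touches the aromatic ring; the one available step concerns the carbonyl end and therefore bears little on this change. A step of no more than the scatter is expected in this assay. Compound 3 is estimated at 3500 nM, with a range of 1200 nM to 10000 nM, which is expected to mean a 1.1-fold higher number from compound 2 to compound 3 (0.04 log units; within the scatter).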

Compound 3, half-maximal inhibitory concentration: 7650 nM
Compound 3: the middle estimate sits 2.2-fold (0.34 log units) below what was measured; measured number inside the range.
By their numbers in this assay, from the lowest: compounds 2, 1 and 3 (each within the scatter of the next, the first and the last beyond it).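

In this assay the change from 4-methylphenyl to 4-fluorophenyl gives a 2.4-fold higher number from compound 2 to compound 3 (0.38 log units; beyond the scatter) and so shows that this aromatic carbon, para to a large group, is sensitive to its substituent, with methyl preferred over fluoro in this pair. The earlier step concerned the carbonyl end and stayed within the scatter, so this is the first change shown to move the number beyond it, though only modestly. Nothing available explains the step. As far as these compounds go, how a chloro, methoxy or amine group would behave at this position remains open. So does whether the same change would have a similar effect with the hydroxyamino end of compound 1.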